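A few compounds are considered here, and "the series" means these few. Any claim that something is new, unique, unknown or untested is made for them only; others in the source may bear on it.

The measured compounds and their values in a functional assay on MDA-MB-231 cells (Homo sapiens) for inhibition, read by MTT assay, with a stated time of 48 h; a higher number here means a weaker inhibitor, a lower number a stronger inhibitor:

compound 1, `CCn1c(/C=C2\SC(=O)N(CC(=O)N3CCCCC3)C2=O)nc2ccccc21`: > 50000 nM, a limit of this assay
compound 2, `Cn1c(/C=C2\SC(=O)N(CC(=O)N3CCCCC3)C2=O)nc2ccccc21`: > 50000 nM, a limit of this assay
compound 3, `Cn1c(/C=C2\SC(=O)N(CC(=O)Nc3nc(-c4ccccc4)cs3)C2=O)nc2ccccc21`: 29200 nM

In this assay compound 1 is given only as a limit, > 50000 nM. Compound 2 likewise reaches only a limit, > 50000 nM. The change from compound 2 to compound 1 is methyl in place of hydrogen on a saturated chain carbon bound to an aromatic nitrogen, and the step it made, a step that the two limits leave unreadable from compound 2 to compound 1, cannot be sized because the limit of > 50000 nM in this assay, at which 2 of the 3 values shown sit, is where both values sit. For the measured compounds named here, compound 3 is the one compound with a number, 29200 nM; how its core differs from that of compound 2 is not broken down here.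

Compound 4, `CCn1c(/C=C2\SC(=O)N(CC(=O)Nc3nc(-c4ccccc4)cs3)C2=O)nc2ccccc21`, has not yet been measured. It differs from compound 3 by methyl in place of hydrogen on a saturated chain carbon bound to an aromatic nitrogen, the same change as that from compound 2 to compound 1, made here on the core shared by compound 3 and compound 4. Since the earlier step gave no readable size, there is no basis for expecting a large movement in either direction; the account therefore rests on compound 3 alone, whose value 29200 nM is taken as the anchor. The step of a 1.0-fold higher number from compound 3 to compound 4 (0.01 log units; within the scatter) is expected to be small. In this assay compound 4 is estimated at 30000 nM, with a range from 12000 nM to 50000 nM.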

Compound 4, half-maximal inhibitory concentration: > 50000 nM
Compound 4: no number, only a limit; the forecaster's own chance of this, stated with the estimate: 35%; at least 1.6-fold (0.22 log units) between middle value and limit.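

Carried onto the core of compound 3, the change of methyl in place of hydrogen on a saturated chain carbon bound to an aromatic nitrogen gives, in this assay, an at least 1.7-fold higher number from compound 3 to compound 4 (0.23 log units; that floor lies within the scatter), and this is the only size that can be put on the change, with compound 4 standing as a limit and not a number. For the compounds shown here, the step from compound 2 to compound 1 cannot be read, so the two cores offer no pair of sizes to set side by side, and nothing shows whether the change behaves alike or differently on them. Since only a floor is printed for the new step and that floor lies within the scatter, a real weakening on the core of compound 3 is not established, and the readings in this small series end at one shared edge: the limit of > 50000 nM in this assay, at which 3 of the 4 values shown sit.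

The compounds shown leave open whether a longer chain such as propyl in place of the ethyl of compound 4, or a chain ending in an amine or a carboxylic acid, would give a number rather than a limit. They also leave open how far past the limit compound 1, compound 2 and compound 4 lie, and so how large the change really is on either core.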